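The source may report more compounds than this note shows. Statements on the series, on what has been measured and on what is new or still open speak of the compounds shown alone.

Compound 1 `CCC(CC)c1ccc2c(NCCCNCc3cc(F)ccc3OC)ccnc2c1` and compound 2 `CCC(CC)c1ccc2c(NCCCNCc3cccc(OC)c3O)ccnc2c1` share one core and differ only in the aryl group carried on the saturated chain carbon bound to an amine nitrogen. In a physicochemical assay for acid dissociation, compound 1 gives 9.47, and compound 2 gives 9.47; the step from compound 1 to compound 2 was no change at the digits printed from compound 1 to compound 2 (within the scatter). Compound 1 thus stands level with compound 2 at the digits shown.

Compound 3 `COc1ccc(F)cc1CNCCCNc1ccnc2cc(-c3ccc(C(C)(C)C)cc3)ccc12` has not yet been measured. It differs from compound 1 in a different part of the molecule: 4-(tert-butyl)phenyl in place of pentan-3-yl on an aromatic carbon. Among the compounds with values here, no measured step touches this aromatic carbon, and the only step known, from a change at the other end of the molecule, stayed within the scatter. On that slim basis the proton is expected to be given up about as readily in compound 3, and the estimated step is a number 0.07 log units lower from compound 1 to compound 3 (within the scatter). Compound 3 is therefore estimated at 9.4, within a range from 9 to 9.8.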

Compound 3, acid dissociation constant: 9.47
Estimate against measurement, compound 3: 0.07 log units below; measured number inside the range.
By their numbers in this assay, from the lowest: compounds 1, 2 and 3 (each within the scatter of the next).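

In this assay, putting 4-(tert-butyl)phenyl in place of pentan-3-yl on this aromatic carbon gave no change at the digits printed from compound 1 to compound 3 (within the scatter). Within the data shown here, this is the first reading at this position, as the earlier step concerned the aryl group at the other end of the molecule; here, a larger group carrying an aromatic ring of its own leaves the number level. Nothing measured here accounts for this result.

It remains open whether an amine or a carboxylic acid on this same aromatic carbon would also leave the reading level, since both groups shown here consist of carbon only. A longer chain linking the two amine nitrogens is a separate open question, and the compounds shown do not reveal which proton this number reports.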